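A few compounds are considered here, and "the series" means these few. Any claim that something is new, unique, unknown or untested is made for them only; others in the source may bear on it.

Compound 1 `COc1cccc(/C=C/C(=O)c2ccc[nH]2)c1` — 6200 nM in an assay for inhibition of cytochrome P450 1A1 (Homo sapiens), read by fluorescence, using microsomes, with a stated time of 10 min; on this read-out lower numbers stand for stronger inhibition and higher numbers for weaker inhibition
Compound 2 `COc1ccc(/C=C/C(=O)c2ccc[nH]2)cc1Br` — > 20000 nM, a limit only

Compound 2 gives no number in this assay, only a limit (the limit of > 20000 nM in this assay, at which 1 of the 2 values shown sits), so it stands at the weak end of what is shown. Compound 3 `O=C(/C=C/c1cccc(Br)c1)c1ccc[nH]1` differs from compound 2 in one place: hydrogen in place of methoxy on an aromatic carbon. Within the data shown here, no measured pair shows this change, so its size is uncertain. Compound 1, which carries a methoxy without the bromo group, gives 6200 nM. The step of an at least 2.0-fold lower number from compound 2 to compound 3 (0.30 log units; that floor lies within the scatter) is estimated as a modest move toward stronger inhibition. For compound 3 the expected value is 10000 nM, with a range from 3000 nM to 40000 nM.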

Compound 3, half-maximal inhibitory concentration: > 20000 nM
Compound 3 ended at the assay's limit; the forecaster's own chance of this, stated with the estimate: 35%; at least 2.0-fold (0.30 log units) between middle value and limit.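

Taking the methoxy off compound 2 leaves compound 3 still without a number, so this change cannot be sized, and both values are only limits: the limit of > 20000 nM in this assay, at which 2 of the 3 values shown sit.

The readable comparison comes from compound 1, where bromo in place of methoxy gives an at least 3.2-fold higher number from compound 1 to compound 3 (0.50 log units; beyond the scatter) in this assay. Among these compounds, then, a measurable value goes with the methoxy of compound 1, and swapping it for bromo loses that value.

As far as these compounds go, how weak compound 2 and compound 3 really are stays unknown. From the compounds shown here alone, whether an amine or a hydroxyl in place of that bromo would return a measurable value also stays open.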